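A few compounds are considered here, and "the series" means these few. Any claim that something is new, unique, unknown or untested is made for them only; others in the source may bear on it.

Measured in a physicochemical assay for solubility, at 21 degrees C; a lower number here means a less soluble compound, a higher number a more soluble compound:
- compound 1 `CCOC(=O)CNC(=O)COC(=O)c1ccccc1OC(C)=O`: 4320 ug/mL
- compound 2 `CCOC(=O)CN(C)C(=O)COC(=O)c1ccccc1OC(C)=O`: 960 ug/mL
- compound 3 `CC(=O)OCOC(=O)c1ccccc1OC(C)=O`: 2430 ug/mL

Compound 3, at 2430 ug/mL, lies within the scatter of compound 1, at 4320 ug/mL. Within the data shown here, compound 2 gives 960 ug/mL, and the gap between that number and the one of compound 3 exceeds the scatter.

The next structure, compound 4 `COC(=O)c1ccccc1OC(C)=O`, has not yet been measured in this assay. Its difference from compound 3 is this: hydrogen in place of acetoxy on a saturated chain carbon bound to an oxygen next to a carbonyl group. In words, it has hydrogen in place of acetoxy on a saturated chain carbon bound to an oxygen next to a carbonyl group, so that acetoxymethyl becomes methyl.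

Among the measured compounds shown here, no measured step makes this change. For the measured compounds named here, the only step available is a 4.5-fold lower number from compound 1 to compound 2 (0.65 log units; beyond the scatter), which concerns an amide-type nitrogen, a different kind of change. It offers a rough guide to size but none to direction. A step of similar or smaller size is therefore expected in this assay, and a lower number is taken as only slightly the likelier outcome. The estimate means an expected 1.6-fold lower number from compound 3 to compound 4 (0.21 log units; within the scatter). For compound 4 the estimated value is 1500 ug/mL, with an expected range from 600 ug/mL to 3500 ug/mL.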

Compound 4, solubility: 2810 ug/mL
Compound 4: middle estimate off by 1.9-fold (0.27 log units), on the low side; the measured number falls inside the stated range.
By their numbers in this assay, from the lowest: compound 2; then compounds 3, 4 and 1 (each within the scatter of the next).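

In this assay, replacing acetoxy with hydrogen on a saturated chain carbon bound to an oxygen next to a carbonyl group gives a 1.2-fold higher number from compound 3 to compound 4 (0.06 log units; within the scatter) and so stays within the scatter, which means that acetoxymethyl and methyl cannot be told apart at this place on this read-out. Among these compounds, the only earlier step (a 4.5-fold lower number from compound 1 to compound 2 (0.65 log units; beyond the scatter)) concerned an amide-type nitrogen and lay beyond the scatter, whereas this step shows that the loss of a group of 4 heavy atoms from this place need not move the number beyond the scatter. No measurement at hand explains why compound 3 and compound 4 lie so close together.

What the compounds shown leave open is whether other groups at this place, such as an amine, a carboxylic acid or a longer chain, would also stay within the scatter of compound 3 and compound 4. From the compounds shown here alone, the methyl on the amide-type nitrogen also remains a single step on a single pair, so it is open whether the same change would give a step of similar size in a related compound.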